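Ring swap at the saturated ring carbon: compound 1 to compound 3

This account rests on a few compounds, and the source may have more. Where it says the series, first, only, none or still open, it means among the compounds named here.

Measured so far:
compound 1 `O=c1cc[nH]c(=O)n1C1CN(S(=O)(=O)c2ccccc2[N+](=O)[O-])c2ccccc2CO1`: 50900 nM
compound 2 `c1ccc(Sc2nc(Sc3ccccc3)c3ncn(C4CNc5ccccc5CO4)c3n2)cc1`: 9710 nM

In a functional assay on MCF7 cells (Homo sapiens) for cytotoxicity, read by sulforhodamine B assay, with a stated time of 3 days (on this read-out higher numbers stand for weaker inhibition and lower numbers for stronger inhibition), compound 1 gives 50900 nM, the highest of the two numbers. Going by the values given here, compound 2 `c1ccc(Sc2nc(Sc3ccccc3)c3ncn(C4CNc5ccccc5CO4)c3n2)cc1` gives 9710 nM in this assay, a lower number beyond the scatter; the two differ in more than one place, so no single step is drawn between them.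

Compound 3 `O=[N+]([O-])c1ccccc1S(=O)(=O)N1CC(n2cnc3c(Br)ncnc32)OCc2ccccc21` is compound 1 with one change: a group of 10 heavy atoms (5 carbon, 4 nitrogen, 1 bromine; one five-membered aromatic ring with 2 hetero atoms, one six-membered aromatic ring with 2 hetero atoms) in place of a group of 8 heavy atoms (4 carbon, 2 nitrogen, 2 oxygen; one six-membered aromatic ring with 2 hetero atoms), on a saturated ring carbon. Among the compounds with values here, no step between measured compounds covers this change. Within the data shown here, the only other compound at hand, compound 2 with 9710 nM, carries a related pair of aromatic rings on the same saturated ring carbon and sits lower than compound 1, which weakly supports a lower number for compound 3. Compound 3 is expected at 20000 nM, range 6000 nM to 60000 nM. The estimated step of a 2.5-fold lower number from compound 1 to compound 3 (0.41 log units; beyond the scatter) is modest, toward stronger inhibition, barely beyond the scatter.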

Compound 3, half-maximal inhibitory concentration: 3620 nM
Beside the measured number, compound 3's estimate is 5.5-fold (0.74 log units) above it; the measured number lies below the stated range.
By their numbers in this assay, from the lowest: compound 3; then compound 2; then compound 1.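

In this assay, the saturated ring carbon next to the ring oxygen now has its first readable step: on the core of compound 1, the group of 10 heavy atoms, with a five-membered and a six-membered aromatic ring and one bromine, replaces the group of 8 heavy atoms and gives a 14-fold lower number from compound 1 to compound 3 (1.15 log units; beyond the scatter) as a large change beyond the scatter. The number in this cell assay therefore responds strongly to the group carried at this carbon, which neither earlier value could show alone. Nothing measured here accounts for the change.

Since the ring system and the bromine enter together, this single step cannot divide the change between them. From the compounds shown here alone, whether an amine in place of the bromine would keep the lower number remains open.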